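Biphenyl series: acetamido for isopropoxy at the outer ring

The source may report more compounds than this note shows. Statements on the series, on what has been measured and on what is new or still open speak of the compounds shown alone.

Of the compounds shown here, two have a number so far. Compound 1 `CC(C)C[C@H](N)CN(C(=O)[C@@H]1C[C@H]1c1ccccc1)c1ccc(C2=CCCC2)cc1` gives 1200 nM in a functional assay for agonist activity at G protein-coupled receptor 88 (Homo sapiens), read by HTRF and cAMP accumulation; a lower number here means that less compound is needed, a higher number that more compound is needed for the effect. Compound 2 `CC[C@H](C)[C@H](N)CN(C(=O)[C@@H]1C[C@H]1c1ccccc1)c1ccc(-c2ccc(OC(C)C)cc2)cc1` gives 72 nM in this assay, the lower of the two numbers, with the gap to compound 1 beyond the usual scatter. Compound 3 `CC[C@H](C)[C@H](N)CN(C(=O)[C@@H]1C[C@H]1c1ccccc1)c1ccc(-c2ccc(NC(C)=O)cc2)cc1` is unmeasured; it differs from compound 2 by acetamido in place of isopropoxy on an aromatic carbon. Going by the values given here, no step of this kind has been measured, so the direction rests on no precedent. A modest move to a higher number is expected, a 2.8-fold higher number from compound 2 to compound 3 (0.44 log units; beyond the scatter), though a change within the scatter would not surprise. For compound 3 the estimate is 200 nM, with a range of 50 nM to 800 nM.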

Compound 3, half-maximal effective concentration: 5500 nM
Beside the measured number, compound 3's estimate is 28-fold (1.44 log units) below it; measured number above the stated range.
By their numbers in this assay, from the lowest: compound 2; then compound 1; then compound 3.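

On an aromatic carbon para to a large group, this position is sensitive to the identity of the substituent: in this assay, acetamido in place of isopropoxy gives a 76-fold higher number from compound 2 to compound 3 (1.88 log units; beyond the scatter), a large step beyond the scatter. Both groups have the same heavy-atom count, so that count alone does not set the number here, while acetamido adds a hydrogen-bond donor. Nothing available explains the step.

Still open, as far as these compounds go, is whether the amide hydrogen or the carbonyl tracks with the loss. A methoxy group, a primary amine or a carboxylic acid at this position would help separate these readings.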